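Swapping a Methyl for Chloro on a Thiophene Ring

This account rests on a few compounds, and the source may have more. Where it says the series, first, only, none or still open, it means among the compounds named here.

Of the compounds shown here, two built on the same bicyclic amine core have been tested in an ADME assay on MDCK cells (Canis lupus familiaris) for cytotoxicity, read by microscopy, with a stated time of 48 h; a higher number here means that more compound is tolerated, a lower number that less compound is tolerated. Compound 1, `Cc1ccc(CN[C@@H]2C[C@H]3C[C@@H]([C@H]2C)C3(C)C)s1`, carries a 5-methylthiophen-2-yl group on the benzylic-type arm; in this assay compound 1 gives 780 nM. Compound 2, `C[C@H]1[C@H](NCc2sccc2-c2ccccc2)C[C@H]2C[C@@H]1C2(C)C`, carries a phenyl substituent on its thiophene instead; in this assay compound 2 gives 12500 nM. Of these two numbers, compound 1 stands lowest, meaning that cells tolerate less of it than of compound 2, and the gap to compound 2 is wider than ordinary repeat measurements would produce.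

The next compound is compound 3, `C[C@H]1[C@H](NCc2ccc(Cl)s2)C[C@H]2C[C@@H]1C2(C)C`. Relative to compound 1 the change is small: chloro in place of methyl on an aromatic carbon. Methyl leaves, chloro enters, and nothing else on the core or the amine moves. Among the measured compounds shown here, no measured pair here shows what this kind of swap does, so the expectation rests on the change being a single heavy atom on the thiophene. A step from compound 1 to compound 3 of about a 1.3-fold higher number from compound 1 to compound 3 (0.11 log units; within the scatter) is expected, likely within the scatter rather than beyond it. Compound 3 is therefore estimated to give 1000 nM, within a range from 400 nM to 2500 nM.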

Compound 3, minimum cytotoxic concentration: 25000 nM
Compound 3: middle estimate off by 25-fold (1.40 log units), on the low side; measured number outside the range, above it.
By their numbers in this assay, from the lowest: compound 1; then compounds 2 and 3 (each within the scatter of the next).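

At this aromatic carbon next to the ring sulfur, chloro in place of methyl gives a 32-fold higher number from compound 1 to compound 3 (1.51 log units; beyond the scatter) in this assay, so cells tolerate much more of the chloro compound. The exchange is only one heavy atom for one heavy atom, adds no ring and leaves the hydrogen-bond donor and acceptor counts at zero on both groups, yet it moves the number well beyond the scatter, which shows that this single position on the thiophene can matter a great deal in this assay. Among the compounds shown here, nothing measured so far explains why so small a swap has so large a step.

Still open, from the compounds shown here alone, is whether the step belongs to chloro itself or to the loss of methyl, a question that a bromo, a methoxy or a nitrile group on the same aromatic carbon could help to settle. Also open, going by these compounds, is whether chloro would have a similar effect on a thiophene that also carries a phenyl group, as the thiophene of compound 2 does.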